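Swapping sec-butyl for allyl on the amine nitrogen

The compounds below may be only part of what the source reports. "The series", "measured", "known", "first", "only" and "open" are said of these compounds alone.

Measured in a functional assay on HT-29 cells (Homo sapiens) for inhibition, read by MTT assay, with a stated time of 72 h; on this read-out higher numbers stand for weaker inhibition and lower numbers for stronger inhibition:
- Compound 1 `COc1cc(/C=C/C(=O)/C=C(/C=C/c2ccc(OC(C)=O)c(OC)c2)NC2CCCCC2)ccc1OC(C)=O`: > 25000 nM (a limit)
- Compound 2 `CCCNC(=C\C(=O)/C=C/c1ccc(O)c(OC)c1)/C=C/c1ccc(O)c(OC)c1`: 22700 nM
- Compound 3 `CCC(C)NC(=C\C(=O)/C=C/c1ccc(O)c(OC)c1)/C=C/c1ccc(O)c(OC)c1`: > 25000 nM (a limit)

Compound 3 has no exact number, only a limit. It sits at the limit of > 25000 nM in this assay, at which 2 of the 3 values shown sit. Compound 4 `C=CCNC(=C\C(=O)/C=C/c1ccc(O)c(OC)c1)/C=C/c1ccc(O)c(OC)c1` differs from it as follows: allyl in place of sec-butyl on an amine nitrogen. So allyl stands in place of sec-butyl on the amine nitrogen. Among the measured compounds shown here, one measured step bears on this change, a methyl added to the chain on that nitrogen: an at least 1.1-fold higher number from compound 2 to compound 3 (0.04 log units; that floor lies within the scatter). With so small a step on record, little change is expected in this assay. The expected step, no larger than the scatter, is an at least 1.1-fold lower number from compound 3 to compound 4 (0.05 log units; that floor lies within the scatter). For compound 4 the estimated value is 22000 nM, with an expected range of 11000 nM to 35000 nM.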

Compound 4, half-maximal inhibitory concentration: > 25000 nM
Compound 4: only a limit was reported; the forecaster's own chance of this, stated with the estimate: 45%; middle value at least 1.1-fold (0.05 log units) away from the limit.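

In this assay compound 4 gives > 25000 nM, which is a limit. The change from sec-butyl to allyl cannot be read, because both compounds carry only a limit: the limit of > 25000 nM in this assay, at which 3 of the 4 values shown sit.

Vinyl in place of ethyl on the chain gives an at least 1.1-fold higher number from compound 2 to compound 4 (0.04 log units; that floor lies within the scatter), a floor and not a true size, so this position still shows no clear gain or loss from the double bond of allyl.

On these data alone, whether a benzyl group or a hydroxyethyl chain on this nitrogen would give a number clearly lower than that of compound 2 remains open.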